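Pyrimidinyl on the Amine Nitrogen: Estimating Compound 4

This account rests on a few compounds, and the source may have more. Where it says the series, first, only, none or still open, it means among the compounds named here.

Measured so far:
Compound 1 `N#CCN(Cc1ccccc1)Cc1ccc2ccccc2c1`: 0%
Compound 2 `N#CCCCN(Cc1ccccc1)Cc1ccc2ccccc2c1`: 0%
Compound 3 `O=C(CN(Cc1ccccc1)Cc1ccc2ccccc2c1)N1CCCCC1`: 0%

In an assay on HEK293 cells for binding affinity to Substance-K receptor (Rattus norvegicus), read by FRET, tested at 10 uM (on this read-out higher numbers stand for more inhibition at the one concentration tested (going by the name of the read-out) and lower numbers for less inhibition), compound 3 stands level with compounds 1 and 2: the step of no change at the digits printed from compound 1 to compound 3 (within the scatter) and the step of no change at the digits printed from compound 2 to compound 3 (within the scatter) both lie within the scatter, as does no change at the digits printed from compound 1 to compound 2 (within the scatter). All three compounds share the same core and differ only in the group on the amine nitrogen, and none of them shows any inhibition.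

Compound 4 `c1ccc(CN(Cc2ccc3ccccc3c2)c2ccncn2)cc1` differs from compound 3 by pyrimidin-4-yl in place of ((piperidin-1-yl)carbonyl)methyl on an amine nitrogen. For the measured compounds named here, no measured step replaces a saturated chain carbon substituent with an aromatic ring on this nitrogen, so the step cannot be read directly from the data; the three known changes on this nitrogen were all flat. The expected step is therefore a number 2 percentage points higher from compound 3 to compound 4 (within the scatter), none beyond the scatter. Compound 4 is estimated to give 2%, with a range from -8% to 15%.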

Compound 4, a percentage reported as inhibition, at one concentration (the size of the read-out at that concentration, not a potency): 34%
For compound 4 the middle estimate is 32 percentage points below the measured one; measured number outside the range, above it.
By their numbers in this assay, from the lowest: compounds 1, 2 and 3 (each within the scatter of the next); then compound 4.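

On the amine nitrogen, the chain groups of compounds 1, 2 and 3 could not be told apart in this assay, so the position looked indifferent to change. Pyrimidin-4-yl shows otherwise, and the rise is large against each of them (a number 34 percentage points higher from compound 3 to compound 4 (beyond the scatter)) (a number 34 percentage points higher from compound 2 to compound 4 (beyond the scatter)) (a number 34 percentage points higher from compound 1 to compound 4 (beyond the scatter)).

Open, going by these compounds, is whether a plain phenyl ring on this nitrogen would do the same, which would show whether the ring itself or its nitrogen atoms count. No measurement shown gives a reason for the rise.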